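The source may report more compounds than this note shows. Statements on the series, on what has been measured and on what is new or still open speak of the compounds shown alone.

Compound 1 `Cc1ccc(S(=O)(=O)Nc2ccc3c(c2)C(=O)N(Cc2ccc(Cl)cc2)C3=O)cc1`, compound 2 `Cc1ccc(S(=O)(=O)Nc2ccc3c(c2)C(=O)N(Cc2ccccc2)C3=O)cc1`, compound 3 `Cc1ccc(S(=O)(=O)Nc2ccc3c(c2)C(=O)N(CCNc2ccccc2)C3=O)cc1`; compound 4 `Cc1ccc(S(=O)(=O)Nc2ccc3c(c2)C(=O)N(Cc2ccc(Cl)c(Cl)c2)C3=O)cc1` awaits measurement.

In an assay on isolated protein for inhibition of lysosomal alpha-glucosidase (Rattus norvegicus), read by colorimetric assay (a lower number here means a stronger inhibitor, a higher number a weaker inhibitor), compound 1 gives 188000 nM. Compound 3 gives 99600 nM. For compound 2 the value > 200000 nM is a limit of the assay and not a number (the limit of > 200000 nM in this assay, at which 1 of the 3 values shown sits). Compound 1 stands highest of the two numbers; its step to compound 3 is a 1.9-fold lower number from compound 1 to compound 3 (0.28 log units; within the scatter). The change to compound 4 is chloro in place of hydrogen on an aromatic carbon. The step that bears on it is an at least 1.0-fold higher number from compound 1 to compound 2 (0.02 log units; that floor lies within the scatter), the same group lost in the other direction; the step of an at least 2.0-fold lower number from compound 2 to compound 3 (0.30 log units; that floor lies within the scatter) concerns the chain carbon and says little here. Neither step leaves the scatter, so for compound 4 no step beyond the scatter is expected in this assay. The estimate for compound 4 is 150000 nM, between 70000 nM and 300000 nM, an expected step of a 1.3-fold lower number from compound 1 to compound 4 (0.10 log units; within the scatter).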

Compound 4, half-maximal inhibitory concentration: 122000 nM
Compound 4: middle estimate off by 1.2-fold (0.09 log units), on the high side; low and high end bracket the measured number.
By their numbers in this assay, from the lowest: compounds 3, 4 and 1 (each within the scatter of the next). At a limit, above all of these: compound 2.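

A second chloro, ortho to a chloro group and meta to a large group, gives no separable change in this assay: a 1.5-fold lower number from compound 1 to compound 4 (0.19 log units; within the scatter). Replacing anilinomethyl with 3,4-dichlorophenyl on the chain carbon also leaves the two ends unseparated: a 1.2-fold higher number from compound 3 to compound 4 (0.09 log units; within the scatter). Against a limit, which is not a number, only a floor can be read, an at least 1.6-fold lower number from compound 2 to compound 4 (0.21 log units; that floor lies within the scatter): the limit of > 200000 nM in this assay, at which 1 of the 4 values shown sits.

On these data alone, whether a methoxy group, an amine or a carboxylic acid at this position would move the number beyond the scatter stays open. Every step shown so far remains within it.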